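The compounds below may be only part of what the source reports. "The series", "measured", "known", "first", "only" and "open" are said of these compounds alone.

Measured compounds:
compound 1, `NS(=O)(=O)c1cccc(-c2nnc(-c3ccc(F)cc3)o2)c1`: 975 nM
compound 2, `N#Cc1ccc(C(=O)NNC(=O)c2ccc(S(N)(=O)=O)cc2)cc1`: 1170 nM
compound 3, `NS(=O)(=O)c1ccc(-c2nnc(-c3ccc(Cl)c(Cl)c3)o2)cc1`: 2.7 nM

In an assay on cells for inhibition of Amine oxidase [flavin-containing] B (Homo sapiens), read by fluorescence and spectrophotometry, using microsomes, with a stated time of 20 min (a lower number here means a stronger inhibitor, a higher number a weaker inhibitor), compound 2 has the highest of the three numbers. Its nearest neighbour is compound 1 at 975 nM, a gap that lies within the usual scatter, so the two compounds are not separated by this measurement. The furthest is compound 3 at 2.7 nM, far lower and well beyond the scatter; since compound 3 differs from compound 2 in the core as well as in the substituents, that gap cannot be assigned to any single change.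

Compound 4, `NS(=O)(=O)c1ccc(C(=O)NNC(=O)c2ccc(Cl)cc2)cc1`, has not yet been measured. It differs from compound 2 by chloro in place of cyano on an aromatic carbon. Among the measured compounds shown here, no pair of measured compounds shows this exchange on a shared core, so there is no measured step to lean on. For the measured compounds named here, the author expects a modest step toward a lower number, a 2.3-fold lower number from compound 2 to compound 4 (0.37 log units; beyond the scatter), because compound 3 with 2.7 nM is the only chloro-bearing compound and gives the lowest value, though its different core makes this a weak guide. Compound 4 is therefore estimated at 500 nM, with a range from 100 nM to 2500 nM.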

Compound 4, half-maximal inhibitory concentration: 11700 nM
Compound 4: middle estimate off by 23-fold (1.37 log units), on the low side; measured number above the stated range.
By their numbers in this assay, from the lowest: compound 3; then compounds 1 and 2 (each within the scatter of the next); then compound 4.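

Among the compounds shown here, on the shared core of compound 2, the change from 4-cyanophenyl to 4-chlorophenyl in this assay gives a 10-fold higher number from compound 2 to compound 4 (1.00 log units; beyond the scatter) on an aromatic carbon para to a large group, which is the first measured step at this position. On this core the nitrile therefore goes with the lower number of the pair, and chloro brings no gain here; the chloro-bearing compound 3 has a different core and cannot be read across to this position. Nothing in the available data accounts for the direction or the size of this step.

The compounds shown leave open how other groups at this position would compare with nitrile and chloro, for example a hydrogen, a methoxy group, an amine or a carboxylic acid. They also leave open whether the same exchange would run in the same direction on the core of compound 3, since the step is known on one core only, and a single pair cannot show whether it holds more widely.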